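The compounds below may be only part of what the source reports. "The series", "measured", "known", "first", "only" and "open" are said of these compounds alone.

Measured so far in an ADME assay on L929 cells (Mus musculus) for cytotoxicity, read by resazurin assay, with a stated time of 48 h; on this read-out lower numbers stand for higher toxicity in this test and higher numbers for lower toxicity in this test:
- compound 1 `O=[N+]([O-])c1ccc2nn(Cc3ccccc3)c(OCCCBr)c2c1`: 59000 nM
- compound 2 `O=[N+]([O-])c1ccc2nn(Cc3ccccc3)c(OCCCO)c2c1`: > 256000 nM, a limit and not a number

Compound 2 has no exact value and stands at the limit of > 256000 nM in this assay, at which 1 of the 2 values shown sits. Compound 3 `COCCOc1c2cc([N+](=O)[O-])ccc2nn1Cc1ccccc1` has the same atoms joined differently, 3-hydroxypropoxy becoming 2-methoxyethoxy: methoxy in place of hydroxymethyl on a saturated chain carbon, two bonds along the chain from an oxygen on an aromatic ring. Among the compounds with values here, only one measured step bears on this, and only indirectly: an at least 4.3-fold higher number from compound 1 to compound 2 (0.63 log units; beyond the scatter), which is hydroxy in place of bromo. Within the data shown here, compound 3 carries no bromo, so the step that set compound 1 at 59000 nM apart is not repeated here, and no step of that size is expected. A small move towards lower numbers in this assay is expected, though a result again reported only as a limit remains possible. The expected change is an at least 1.4-fold lower number from compound 2 to compound 3 (0.15 log units; that floor lies within the scatter). For compound 3 the estimated value is 180000 nM, with an expected range from 80000 nM to 400000 nM.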

Compound 3, concentration lethal to 50% of the cells: > 256000 nM
Compound 3: no number, only a limit; the forecaster's own chance of this, stated with the estimate: 45%; middle value at least 1.4-fold (0.15 log units) away from the limit.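

In this assay compound 3 gives > 256000 nM, which is a limit and not a number. The terminal hydroxy of compound 2 is therefore not required to reach this limit: 2-methoxyethoxy, with 0 hydrogen-bond donors in the group that enters, reaches it too, and the change from the bromo-bearing chain gives an at least 4.3-fold higher number from compound 1 to compound 3 (0.63 log units; beyond the scatter). Compound 2 and compound 3 cannot be ordered and the step between them cannot be read, because both stop at the same limit: the limit of > 256000 nM in this assay, at which 2 of the 3 values shown sit.

Within the data shown here, compound 1, at 59000 nM, is the only compound of the three with a measured number in this assay, so how far the other two lie from it remains unknown. Also open, from the compounds shown here alone, is whether a chain ending in an amine or a carboxylic acid, or a longer chain, would give a measurable value.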